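Hydroxyethyl extension on the shared core: next ring nitrogen

The source may report more compounds than this note shows. Statements on the series, on what has been measured and on what is new or still open speak of the compounds shown alone.

Within the data shown here, compound 1 `Cn1c(Cc2nn(C)c(=O)c3ccccc23)nnc1SCC(=O)Nc1ccc(Cl)cc1Cl` is the only member of the series with a number in an assay on NK92 cells for inhibition of interleukin-2 (Homo sapiens), read by AlphaScreen, with stated times of 30 min and 1 h (on this read-out higher numbers stand for weaker inhibition and lower numbers for stronger inhibition), where compound 1 gives 7700 nM. Compound 2 `Cn1nc(Cc2nnc(SCC(=O)Nc3ccc(Cl)cc3Cl)n2CCCO)c2ccccc2c1=O` carries a 2-hydroxyethyl in place of hydrogen on a saturated chain carbon bound to an aromatic nitrogen; in this assay compound 2 reaches only the limit of > 30000 nM, which is a limit of the assay and not a number. The step of an at least 3.8-fold higher number from compound 1 to compound 2 (0.59 log units; beyond the scatter) is therefore read against (the limit of > 30000 nM in this assay, at which 1 of the 2 values shown sits).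

Compound 3 `Cn1c(Cc2nn(CCCO)c(=O)c3ccccc23)nnc1SCC(=O)Nc1ccc(Cl)cc1Cl` is not yet measured. It differs from compound 1 by 2-hydroxyethyl in place of hydrogen on a saturated chain carbon bound to an aromatic nitrogen. Among the measured compounds shown here, the one measured step of the same kind is an at least 3.8-fold higher number from compound 1 to compound 2 (0.59 log units; beyond the scatter), which moved the number into the limit region. On that basis the expectation for this assay is a step of similar direction, that is a higher number and weaker inhibition, of a size that may again run up against the limit. The expected step is a 2.9-fold higher number from compound 1 to compound 3 (0.46 log units; beyond the scatter). For compound 3 in this assay the estimate is 22000 nM, with a range from 8000 nM to 60000 nM.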

Compound 3, half-maximal inhibitory concentration: > 30000 nM
Compound 3 was reported as a limit; the forecaster's own chance of this, stated with the estimate: 40%; at least 1.3-fold (0.13 log units) between middle value and limit.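

In this assay, the change from methyl to 3-hydroxypropyl now appears at a second place on the shared core, again as 2-hydroxyethyl in place of hydrogen on a saturated chain carbon bound to an aromatic nitrogen, and gives an at least 3.8-fold higher number from compound 1 to compound 3 (0.59 log units; beyond the scatter). Compound 3 gives > 30000 nM, which is a limit of the assay and not a number. Among the compounds shown, the change therefore weakens inhibition beyond the usual scatter at both places, with no compound going against this, but the true size of the loss stays unknown and the two places cannot be ranked against each other: the limit of > 30000 nM in this assay, at which 2 of the 3 values shown sit.

The compounds shown leave open whether the loss goes with the terminal hydroxyl or with the chain itself, a question that a plain propyl or a 3-methoxypropyl at either place would address. They also leave open whether a shorter ethyl chain, or a 3-aminopropyl group with an amine at the chain end, would keep a number below the limit of the assay.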